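Removing the fluoro from compound 1: a para-substituent test

The compounds below may be only part of what the source reports. "The series", "measured", "known", "first", "only" and "open" are said of these compounds alone.

Measured so far in a functional assay on B16-F10 cells (Mus musculus) for inhibition, read by MTT assay, with a stated time of 72 h; on this read-out higher numbers stand for weaker inhibition and lower numbers for stronger inhibition:
compound 1 `CC(C)c1ccc(-c2nc(SCc3cn(CC(=O)NC(=O)Nc4ccccn4)nn3)nc(Nc3ccc(F)cc3)c2C#N)cc1`: 7250 nM
compound 2 `CC(C)c1ccc(-c2nc(SCc3cn(CC(=O)NC(=O)Nc4ccccn4)nn3)nc(Nc3ccc(Cl)cc3)c2C#N)cc1`: 860 nM
compound 3 `CC(C)c1ccc(-c2nc(SCc3cn(CC(=O)NC(=O)Nc4ccccn4)nn3)nc(Nc3cccc([N+](=O)[O-])c3)c2C#N)cc1`: 26400 nM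

Compound 1 stands second highest of the three numbers in this assay. Its nearest neighbour is compound 3, reached by a 3.6-fold higher number from compound 1 to compound 3 (0.56 log units; beyond the scatter); the furthest is compound 2, reached by an 8.4-fold lower number from compound 1 to compound 2 (0.93 log units; beyond the scatter). Among the measured compounds shown here, the only step in which a single substituent is swapped on that aromatic carbon is the one from compound 1 to compound 2, and it was modest yet beyond the scatter.

Compound 4 `CC(C)c1ccc(-c2nc(SCc3cn(CC(=O)NC(=O)Nc4ccccn4)nn3)nc(Nc3ccccc3)c2C#N)cc1` differs from compound 1 by hydrogen in place of fluoro on an aromatic carbon. For the measured compounds named here, no measured step removes a group from that position outright, so the chloro-for-fluoro step and the larger change to the 3-nitrophenyl ring are the only guides. Both suggest this position is sensitive, but neither tells which way a loss of the fluoro should move the number. The expectation is therefore a small step, a 1.2-fold higher number from compound 1 to compound 4 (0.09 log units; within the scatter), probably not beyond the scatter. Compound 4 is estimated at 9000 nM, with a range from 3500 nM to 25000 nM.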

Compound 4, half-maximal inhibitory concentration: 14300 nM
Estimate against measurement, compound 4: 1.6-fold (0.20 log units) below; measured number inside the range.
By their numbers in this assay, from the lowest: compound 2; then compounds 1, 4 and 3 (each within the scatter of the next, the first and the last beyond it).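

Among the compounds shown here, removing the fluoro gives no step that can be told from the scatter in this assay (a 2.0-fold higher number from compound 1 to compound 4 (0.29 log units; within the scatter)), and the phenyl ring of compound 4 likewise cannot be told from the 3-nitrophenyl ring (a 1.8-fold lower number from compound 3 to compound 4 (0.27 log units; within the scatter)). Removing the chloro, by contrast, is a large step (a 17-fold higher number from compound 2 to compound 4 (1.22 log units; beyond the scatter)), so the position's sensitivity shows up in compound 2, which alone stands beyond the scatter from each of the other three compounds. The data offer no measurement that explains why the chloro and the fluoro part ways here.

From the compounds shown here alone, whether the low number of compound 2 is particular to the chloro stays open: a bromo, a methyl or a methoxy on the same aromatic carbon would test that. The compounds shown also leave open whether the chloro step would hold on a different core.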